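Aryl swaps on the enone terminus: cytotoxicity holds steady

A few compounds are considered here, and "the series" means these few. Any claim that something is new, unique, unknown or untested is made for them only; others in the source may bear on it.

Among the compounds with values here, the series shares one core carrying a sulfonylurea and an enone; the three measured members differ only in the aryl group on a double-bonded chain carbon bound to a double-bonded chain carbon. In an ADME assay on the whole organism for cytotoxicity, with Artemia salina as the target, with a stated time of 24 h (a higher number here means that more compound is needed for the effect, a lower number that less compound is needed), compound 1 `Cc1ccc(/C=C/C(=O)c2ccccc2NC(=O)NS(=O)(=O)c2ccc(C)cc2)cc1` gives 15.3 ug/mL, compound 2 `CCc1cc(/C=C/C(=O)c2ccccc2NC(=O)NS(=O)(=O)c2ccc(C)cc2)cc(OC)c1OC` gives 19.2 ug/mL and compound 3 `Cc1ccc(S(=O)(=O)NC(=O)Nc2ccccc2C(=O)/C=C/c2cc(O)ccc2[N+](=O)[O-])cc1` gives 18.3 ug/mL. Compound 2 stands alongside the other two: the step of a 1.3-fold higher number from compound 1 to compound 2 (0.10 log units; within the scatter) and the step of a 1.0-fold lower number from compound 2 to compound 3 (0.02 log units; within the scatter) are both within the scatter, as is a 1.2-fold higher number from compound 1 to compound 3 (0.08 log units; within the scatter), so the three aryl groups tried so far cannot be told apart in this assay.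

Compound 4 `Cc1ccc(S(=O)(=O)NC(=O)Nc2ccccc2C(=O)/C=C/c2ccc(F)cc2)cc1` continues the same kind of change: 4-fluorophenyl in place of 3-ethyl-4,5-dimethoxyphenyl on a double-bonded chain carbon bound to a double-bonded chain carbon. Every step measured at this position, a 1.3-fold higher number from compound 1 to compound 2 (0.10 log units; within the scatter), a 1.2-fold higher number from compound 1 to compound 3 (0.08 log units; within the scatter) and a 1.0-fold lower number from compound 2 to compound 3 (0.02 log units; within the scatter), stayed within the scatter despite substantial differences in the groups exchanged. The expectation for this assay is therefore no step beyond the scatter, in either direction, and the estimated step is a 1.1-fold lower number from compound 2 to compound 4 (0.05 log units; within the scatter). Compound 4 is accordingly expected to give about 17 ug/mL, with a plausible range from 9 ug/mL to 34 ug/mL.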

Compound 4, concentration for half-maximal effect: 3.96 ug/mL
The estimate for compound 4 lay 4.3-fold (0.63 log units) above the measured number; the measured number lies below the stated range.
By their numbers in this assay, from the lowest: compound 4; then compounds 1, 3 and 2 (each within the scatter of the next).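

In this assay, the aryl group on a double-bonded chain carbon bound to a double-bonded chain carbon now proves able to shift the number: 4-fluorophenyl stands apart from the earlier groups, with a 4.8-fold lower number from compound 2 to compound 4 (0.69 log units; beyond the scatter) and a 4.6-fold lower number from compound 3 to compound 4 (0.66 log units; beyond the scatter) both read as steps beyond the scatter. The exchange need not be large, as fluoro in place of methyl on an aromatic carbon gives a 3.9-fold lower number from compound 1 to compound 4 (0.59 log units; beyond the scatter) as a step beyond the scatter, whereas the steps among compound 1, compound 2 and compound 3 all stayed within it. No supporting data at hand account for this departure.

With a single fluorinated member in the series, the compounds shown leave open whether the lower number is particular to fluoro or would also appear with chloro or bromo in its place. Also open, as far as these compounds go, is how an unsubstituted phenyl would compare, which would show whether the fluoro lowers the number or the methyl of compound 1 and the larger substitution patterns of compound 2 and compound 3 simply do not.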